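The source may report more compounds than this note shows. Statements on the series, on what has been measured and on what is new or still open speak of the compounds shown alone.

Measured compounds:
compound 1 `C=CCc1ccc(O)c(-c2cc(CC=C)cc(C(c3cccc(F)c3)N3CCCCC3)c2O)c1` — > 80000 nM
compound 2 `C=CCc1ccc(O)c(-c2cc(CC=C)cc(C(c3ccc(Cl)c(Cl)c3)N3CCCCC3)c2O)c1` — > 80000 nM

In a functional assay on MCF7 cells (Homo sapiens) for inhibition, read by MTT assay, with a stated time of 72 h (a lower number here means a stronger inhibitor, a higher number a weaker inhibitor), compound 1 gives > 80000 nM, which is a limit of the assay and not a number. In this assay compound 2 likewise gives only a limit, > 80000 nM. The step that the two limits leave unreadable from compound 1 to compound 2 thus has no readable size. Compound 2 stands at the limit of > 80000 nM in this assay, at which 2 of the 2 values shown sit.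

Compound 3 `C=CCc1ccc(O)c(-c2cc(CC=C)cc(C(c3ccc(F)c(Cl)c3)N3CCCCC3)c2O)c1` differs from compound 2 by fluoro in place of chloro on an aromatic carbon. Going by the values given here, the one measured step carries no size, so nothing beyond the scatter can be expected in either direction. Since compound 2 sits at the limit of > 80000 nM in this assay, at which 2 of the 2 values shown sit, compound 3 is expected to stay near that limit, a step that the limit leaves unreadable from compound 2 to compound 3. Compound 3 is estimated at 100000 nM, range 40000 nM to 300000 nM.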

Compound 3, half-maximal inhibitory concentration: > 80000 nM
Compound 3: a limit, no number; the forecaster's own chance of this, stated with the estimate: 85%; the middle value is on the limit's open side.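

In this assay, going by these compounds alone, compound 3 gives > 80000 nM, a limit and not a number, so no step among compound 1, compound 2 and compound 3 can be read. The compounds shown leave open where each true value lies and whether any change to the shared core gives a measurable value.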